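The compounds below may be only part of what the source reports. "The series", "measured", "known", "first", "only" and "open" are said of these compounds alone.

Compound 1 `CC[C@@H]1C(=O)N(C)c2cnc(-n3ccnc3-c3ccccc3)nc2N1C1CCCC1`: 5 nM
Compound 2 `CCC1C(=O)N(C)c2cnc(-n3ccnc3-c3ccc(F)cc3)nc2N1c1ccc(F)cc1`: 15 nM

In an assay on isolated protein for inhibition of serine/threonine-protein kinase PLK2 (Homo sapiens), read by TR-FRET, with a stated time of 60 min (a higher number here means a weaker inhibitor, a lower number a stronger inhibitor), compound 1 gives 5 nM, the lower of the two numbers recorded; compound 2 gives 15 nM, and the gap between the two lies beyond the usual scatter. Compound 3 `CC[C@@H]1C(=O)N(C)c2cnc(-n3ccnc3-c3ccccc3)nc2N1CCC(F)(F)F` has not yet been measured. It differs from compound 1 by 3,3,3-trifluoropropyl in place of cyclopentyl on a nitrogen on an aromatic ring in a ring. For the measured compounds named here, no measured pair shows a change of this kind, so the size of the step is open; a moderate rise in the number, beyond the scatter, is expected. Compound 3 is estimated to give 15 nM in this assay, within a range from 4 nM to 60 nM. For compound 3 the expected step is a 3.0-fold higher number from compound 1 to compound 3 (0.48 log units; beyond the scatter).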

Compound 3, half-maximal inhibitory concentration: 9 nM
For compound 3 the middle estimate is 1.7-fold (0.22 log units) above the measured one; the range from low to high includes it.
By their numbers in this assay, from the lowest: compounds 1, 3 and 2 (each within the scatter of the next, the first and the last beyond it).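

In this assay the change to 3,3,3-trifluoropropyl in place of cyclopentyl on this nitrogen gives a 1.8-fold higher number from compound 1 to compound 3 (0.26 log units; within the scatter) and so shows that a ring is not required here: an open chain serves as well within the scatter. Compounds 1 and 2 differ in more than one place and could not show this. Nothing shown gives a reason for the result.

Going by these compounds, whether an amine, a hydroxyl group or a longer chain would be accepted on this nitrogen remains open. The plain propyl group is also absent from the compounds shown, so the part played by the fluorine atoms cannot be separated from that of the chain.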